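Methoxy to trifluoromethyl swap in a growth-inhibition series

The source may hold more compounds than are shown below. What is called first, only, known or untested is meant among the compounds shown, and "the series" means these compounds.

Measured compounds:
compound 1, `COc1ccccc1NC(=O)C1NCCc2ccccc21`: > 10000 nM
compound 2, `COc1ccc(NC(=O)C2NCCc3ccccc32)cc1`: > 10000 nM
compound 3, `O=C(Nc1ccc(C(F)(F)F)cc1)C1NCCc2ccccc21`: 4220 nM

All readings come from a functional assay on NUGC-3 cells (Homo sapiens) for inhibition, read by sulforhodamine B assay, with a stated time of 48 h; a higher number here means a weaker inhibitor of growth, a lower number a stronger inhibitor of growth. For compound 1 the value > 10000 nM is a limit of the assay, not a number. For compound 2 the value > 10000 nM is likewise a limit. Compound 3 gives 4220 nM. The change from compound 2 to compound 3 is trifluoromethyl in place of methoxy on an aromatic carbon; it made an at least 2.3-fold lower number from compound 2 to compound 3 (0.37 log units; beyond the scatter). Compound 1 and compound 2 share the same atoms joined differently; the difference between the two cores is not broken down here. Compound 1 rests at the limit of > 10000 nM in this assay, at which 2 of the 3 values shown sit.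

Compound 4, `O=C(Nc1ccccc1C(F)(F)F)C1NCCc2ccccc21`, is not yet measured in this assay. It arises from compound 1 by trifluoromethyl in place of methoxy on an aromatic carbon. This is the same kind of change as that from compound 2 to compound 3, but the place differs: in compound 3 the trifluoromethyl sits para to a large group, in compound 4 ortho to a large group. Compound 4 is expected to give about 6000 nM. The expected range for compound 4 is 2500 nM to 20000 nM. For compound 4 this means an expected step of an at least 1.6-fold lower number from compound 1 to compound 4 (0.22 log units; that floor lies within the scatter). That expectation rests on the measured step of an at least 2.3-fold lower number from compound 2 to compound 3 (0.37 log units; beyond the scatter) and on compound 1 sitting at a limit, so a reading at the limit remains possible.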

Compound 4, concentration for 50% growth inhibition: > 10000 nM
Compound 4 was reported as a limit; the forecaster's own chance of this, stated with the estimate: 45%; middle value at least 1.6-fold (0.22 log units) from the limit.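

In this assay compound 4 gives > 10000 nM, a limit of the assay and not a number. Compound 1 also sits at a limit, so no step can be read between compound 1 and compound 4. Still open, from the compounds shown here alone, is whether trifluoromethyl in place of methoxy changes growth inhibition at all when ortho to a large group.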